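Aryl swap on the ring nitrogen, compared across two cores

A few compounds are considered here, and "the series" means these few. Any claim that something is new, unique, unknown or untested is made for them only; others in the source may bear on it.

The set pairs two cores that carry the same side chain. Compound 1 `CCc1ccccc1-n1cc(COc2ccc(/C=C/C(=O)c3cc4c(cc3O)OC(C)(C)CC4)cc2)nn1` and compound 2 `Cc1ccc(-n2cc(COc3ccc(/C=C/C(=O)c4cc5c(cc4O)OC(C)(C)CC5)cc3)nn2)cc1Br` share one core; compound 3 `CCc1ccccc1-n1cc(COc2ccc(/C=C/C(=O)c3ccc4c(c3O)CCC(C)(C)O4)cc2)nn1` and compound 4 `Cc1ccc(-n2cc(COc3ccc(/C=C/C(=O)c4ccc5c(c4O)CCC(C)(C)O5)cc3)nn2)cc1Br` share the other. Compound 3 and compound 1 have the same atoms joined differently; the difference between the two cores is not broken down here.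

In a functional assay on A549 cells (Homo sapiens) for antiproliferative activity, read by MTT assay (a lower number here means a stronger inhibitor, a higher number a weaker inhibitor), compound 1 gives 137000 nM, compound 2 gives 125000 nM and compound 3 gives 112000 nM. All three numbers lie within the scatter of one another, so no order among them is drawn.

The change from compound 1 to compound 2, (3-bromo-4-methylphenyl in place of 2-ethylphenyl on an aromatic nitrogen), made a step of a 1.1-fold lower number from compound 1 to compound 2 (0.04 log units; within the scatter). The same change is now carried over to the second core, (3-bromo-4-methylphenyl in place of 2-ethylphenyl on an aromatic nitrogen); both place descriptions read the same word for word, so it is the same change. Among the compounds shown it occurs twice and rests on a single measured step.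

For compound 4 a step of a 1.1-fold lower number from compound 3 to compound 4 (0.05 log units; within the scatter) is expected. Going by the values given here, this rests on the step of a 1.1-fold lower number from compound 1 to compound 2 (0.04 log units; within the scatter), the only measurement of this change. For compound 4 the estimate in this assay is 100000 nM, with a range from 50000 nM to 200000 nM.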

Compound 4, half-maximal inhibitory concentration: "not active" (no number reported)
The entry for compound 4 holds no number, and the estimate cannot be compared.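

In this assay, going by these compounds alone, compound 4 is entered as "not active" without a number, so no step from compound 3 to compound 4 can be read. The compounds shown leave open whether 3-bromo-4-methylphenyl in place of 2-ethylphenyl has the same size of effect on both cores. Nothing available bears on this result.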